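The compounds below may be only part of what the source reports. "The series", "measured", "known", "first", "only" and "open" are said of these compounds alone.

Measured in a functional assay on SK-BR-3 cells (Homo sapiens) for antiproliferative activity, read by MTT assay, with a stated time of 72 h; a higher number here means a weaker inhibitor, a lower number a stronger inhibitor:
Compound 1 `C/C=C1/[C@H](O[C@@H]2O[C@H](CO)[C@@H](O)[C@H](O)[C@H]2O)OC=C(C(=O)OC)[C@H]1CC(=O)OCCc1ccc(F)cc1`: > 20000 nM, a limit
Compound 2 `C/C=C1/[C@H](O[C@@H]2O[C@H](CO)[C@@H](O)[C@H](O)[C@H]2O)OC=C(C(=O)OC)[C@H]1CC(=O)OCCc1ccc([N+](=O)[O-])cc1`: > 20000 nM, a limit
Compound 3 `C/C=C1/[C@H](O[C@@H]2O[C@H](CO)[C@@H](O)[C@H](O)[C@H]2O)OC=C(C(=O)OC)[C@H]1CC(=O)OCCC(C)C`: 9020 nM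

For the measured compounds named here, compound 3 carries the only true number in this assay. Its two companions stop at the limit of > 20000 nM in this assay, at which 2 of the 3 values shown sit.

Compound 4 `C/C=C1/[C@H](O[C@@H]2O[C@H](CO)[C@@H](O)[C@H](O)[C@H]2O)OC=C(C(=O)OC)[C@H]1CC(=O)OCCc1ccccc1` differs from compound 3 by phenyl in place of isopropyl on a saturated chain carbon, two bonds along the chain from an oxygen next to a carbonyl group. Going by the values given here, two measured steps bear on this change, and both run the opposite way: an at least 2.2-fold lower number from compound 1 to compound 3 (0.34 log units; beyond the scatter) and an at least 2.2-fold lower number from compound 2 to compound 3 (0.34 log units; beyond the scatter). Each puts isopropyl in place of a substituted phenyl, so a rise of modest size in the number is expected in this assay. The expected step is a 2.1-fold higher number from compound 3 to compound 4 (0.32 log units; beyond the scatter). For compound 4 the estimate is 19000 nM, with an expected range of 9000 nM to 40000 nM.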

Compound 4, half-maximal inhibitory concentration: 11000 nM
Beside the measured number, compound 4's estimate is 1.7-fold (0.24 log units) above it; the measured number falls inside the stated range.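

In this assay, phenyl for isopropyl at this position leaves the number within the scatter: a 1.2-fold higher number from compound 3 to compound 4 (0.09 log units; within the scatter). The phenyl group alone therefore does not account for the gap that separated compound 3 from the substituted phenyl compounds. Removing the ring substituent gives an at least 1.8-fold lower number from compound 2 to compound 4 (0.25 log units; that floor lies within the scatter) and an at least 1.8-fold lower number from compound 1 to compound 4 (0.25 log units; that floor lies within the scatter), but these floors do not establish a real effect of nitro or fluoro, since both starting compounds stop at a limit: the limit of > 20000 nM in this assay, at which 2 of the 4 values shown sit.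

Going by these compounds, how far the number of compound 4 truly lies from those of the nitro and fluoro compounds remains open. Also open, on these data alone, is whether an amine or a carboxylic acid on the phenyl ring, or a longer chain, would move the number.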